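A Methyl for a Chlorine on the Sulfonamide Aryl

The compounds below may be only part of what the source reports. "The series", "measured", "known", "first", "only" and "open" are said of these compounds alone.

Compound 1 `O=C(Nc1ccc(S(=O)(=O)Nc2ccccc2)cc1)c1cc(F)c(Cl)cc1F` gives 141 nM in a functional assay on HEK293 cells for agonist activity at probable G-protein coupled receptor 27 (Homo sapiens), read by a luciferase reporter and beta-arrestin recruitment, with a stated time of 10 min; on this read-out higher numbers stand for an effect only at larger amounts of compound and lower numbers for an effect already at smaller amounts.
Compound 3 `O=C(Nc1ccc(S(=O)(=O)Nc2ccccc2)cc1)c1ccc(I)cc1F` gives 5130 nM in this assay.
Compound 2 `O=C(Nc1ccc(S(=O)(=O)Nc2ccc(Cl)cc2)cc1)c1ccc(Cl)cc1Cl` gives only a limit, > 100000 nM, in this assay.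

The three measured compounds share a core in which an aryl sulfonamide is joined through an amide to a substituted benzoyl group. For the measured compounds named here, the single measured step, a 36-fold higher number from compound 1 to compound 3 (1.56 log units; beyond the scatter), alters the benzoyl group and leaves the sulfonamide aryl untouched. For compound 2 this assay reports no number: compound 2 sits at the limit of > 100000 nM in this assay, at which 1 of the 3 values shown sits.

Compound 4 `Cc1ccc(NS(=O)(=O)c2ccc(NC(=O)c3ccc(Cl)cc3Cl)cc2)cc1` differs from compound 2 in one place: methyl in place of chloro on an aromatic carbon. Going by the values given here, no measured step touches that position, and the step from compound 1 to compound 3 concerns the other end of the molecule, so it gives no guide to the size of this change. Among the compounds with values here, compound 2 shows no measurable effect in this assay, and that limit is the only anchor for compound 4. Compound 4 is expected to remain weak, with an estimate of 60000 nM and a range from 5000 nM to 100000 nM. The step of an at least 1.6-fold lower number from compound 2 to compound 4 (0.22 log units; that floor lies within the scatter) is expected to be small or none, and a limit rather than a number is the more likely outcome.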

Compound 4, half-maximal effective concentration: > 100000 nM
Compound 4 was reported as a limit (the forecaster's own chance of this, stated with the estimate: 60%); middle value at least 1.6-fold (0.22 log units) away from the limit.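

Compound 2 and compound 4 are both reported only as limits in this assay, so no step can be read between them: the limit of > 100000 nM in this assay, at which 2 of the 4 values shown sit.

The compounds shown leave open what methyl in place of chloro on an aromatic carbon does to the half-maximal effective concentration.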